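Shortening the carbonate chain: from isopentyl toward butyl

The source may report more compounds than this note shows. Statements on the series, on what has been measured and on what is new or still open speak of the compounds shown alone.

Measured so far:
compound 1, `CC(C)CCOC(=O)OCC(CO)CCn1cnc2cnc(N)nc21`: 1560 h
compound 2, `CC(C)OC(=O)OCC(CO)CCn1cnc2cnc(N)nc21`: > 4800 h

Compound 1, `CC(C)CCOC(=O)OCC(CO)CCn1cnc2cnc(N)nc21`, carries an isopentyl group on the carbonate oxygen. Going by the values given here, in an ADME assay for pharmacokinetics, read by HPLC, in phosphate buffer, at 37 degrees C, at pH 6.0 (a higher number here means that the compound lasts longer, a lower number that the compound disappears faster), compound 1 gives 1560 h, the only plain number recorded for this series. Compound 2, `CC(C)OC(=O)OCC(CO)CCn1cnc2cnc(N)nc21`, has an isopropyl group in the same position. For compound 2 this assay returns only a limit, > 4800 h, the value at the upper edge of the assay (the limit of > 4800 h in this assay, at which 1 of the 2 values shown sits).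

Among the compounds with values here, the one measured step is an at least 3.0-fold higher number from compound 1 to compound 2 (0.48 log units; beyond the scatter), an at least modest gain on moving to the smaller carbonate chain.

Compound 3, `CCCCOC(=O)OCC(CO)CCn1cnc2cnc(N)nc21`, is the butyl carbonate. It differs from compound 1 by hydrogen in place of methyl on a saturated chain carbon bound to two saturated chain carbons. This is a smaller trimming of the chain than the step to compound 2, so the step to compound 2 bears on it only in part. Compound 3 is therefore expected to sit a little above compound 1 or within the scatter of it, an expected step of a 1.4-fold higher number from compound 1 to compound 3 (0.15 log units; within the scatter). The estimated half-life of compound 3 is 2200 h, within a range of 1000 h to 4800 h.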

Compound 3, half-life: 1780 h
For compound 3 the middle estimate is 1.2-fold (0.09 log units) above the measured one; low and high end bracket the measured number.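

Compound 1 and compound 3 cannot be told apart in this assay, the step being a 1.1-fold higher number from compound 1 to compound 3 (0.06 log units; within the scatter), so trimming the isopentyl chain to butyl by this one methyl does not produce a readable change at this carbonate. Compound 3 instead falls clearly short of the isopropyl carbonate, with an at least 2.6-fold lower number from compound 2 to compound 3 (0.43 log units; beyond the scatter), which shows that the gain seen for compound 2 does not come with every trimming of the isopentyl chain; among these three carbonates, only the isopropyl one stands apart. The true size of that last step remains unknown, since the number for compound 2 is only a limit: the limit of > 4800 h in this assay, at which 1 of the 3 values shown sits.

The compounds shown leave open whether the isopropyl result goes with the short length of that chain or with its branching, a question that a propyl or an ethyl carbonate would help to separate. They also leave open whether a longer chain, such as a hexyl carbonate, would stay level with compound 1 and compound 3 or would part from them.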